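A bromo group replaces methylsulfanyl in a weakly active pair

A few compounds are considered here, and "the series" means these few. Any claim that something is new, unique, unknown or untested is made for them only; others in the source may bear on it.

Measured so far in a functional assay on KB cells (Homo sapiens) for antiproliferative activity, read by sulforhodamine B assay, with a stated time of 3 days; on this read-out lower numbers stand for an effect already at smaller amounts and higher numbers for an effect only at larger amounts of compound:
Compound 1 `CCCCc1ccc(-c2cc(=O)c3c(o2)C(CC)(CC)C(=O)C(CC)=C3O)cc1`: 111 uM
Compound 2 `CCC1=C(O)c2c(oc(-c3ccc(SC)cc3)cc2=O)C(CC)(CC)C1=O`: > 52.1 uM

Compound 2 has no numerical value in this assay, only a limit: > 52.1 uM. Compound 3 `CCC1=C(O)c2c(oc(-c3ccc(Br)cc3)cc2=O)C(CC)(CC)C1=O` carries bromo in place of methylsulfanyl on an aromatic carbon, para to a large group (bromo in place of methylsulfanyl on an aromatic carbon). For the measured compounds named here, the only measured step bearing on this change is a step that the limit leaves unreadable from compound 1 to compound 2, which also involves the methylsulfanyl group. It gives no size to carry over, so no step beyond the scatter is expected in this assay, in either direction. Going by the values given here, compound 1 provides the only numerical value, 111 uM, so compound 3 is also expected to be weakly active. Compound 3 may return only a limit. The estimate corresponds to an expected step that the limit leaves unreadable from compound 2 to compound 3. Compound 3 is estimated at 70 uM, with an expected range from 25 uM to 150 uM.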

Compound 3, concentration for half-maximal effect: > 48.1 uM
Compound 3 gave a limit, no number; the forecaster's own chance of this, stated with the estimate: 60%; the middle value is on the limit's open side.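

In this assay compound 3 returned only a limit, > 48.1 uM. For the compounds shown here, compound 2 also stands as a limit, > 52.1 uM, so no step among compound 1, compound 2 and compound 3 can be read. On these data alone, how bromo, methylsulfanyl and butyl compare on the shared core remains open.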